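This account rests on a few compounds, and the source may have more. Where it says the series, first, only, none or still open, it means among the compounds named here.

Measured so far:
- compound 1 `COc1cc(C)c(S(=O)(=O)N(C)CCOCC(=O)N2CCC(N3CCN(C(C)C)CC3)CC2)c(C)c1`: in a functional assay on Umbilical vein for antagonist activity at B1 bradykinin receptor (Homo sapiens), using Schild analysis, with a stated time of 30 min (on this read-out lower numbers stand for lower potency and higher numbers for higher potency (the scale is a negative logarithm)), compound 1 gives 8.5
- compound 2 `CN(Cc1ccc(C2=NCCN2)cc1)C(=O)COCCN(C)S(=O)(=O)c1c(Cl)cccc1Cl`: in this assay compound 2 gives 8.5
- compound 3 `CCN(CC)CCN1CCN(C(=O)COCCN(C)S(=O)(=O)c2c(C)cc(OC)cc2C)CC1`: in this assay compound 3 gives 7.8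

Compound 1 and compound 2 read level at the digits shown, which is within the scatter of this kind of measurement, so no order between them can be stated. Compound 3 reads lower than compound 1, and that gap is beyond the scatter. Among the compounds with values here, no pair of measured compounds differs in just one place, so no single step has been characterised.

The next compound is compound 4 `COc1cc(C)c(S(=O)(=O)N(C)CCOCC(=O)N2CCC(C3CCN(C(C)C)CC3)CC2)c(C)c1`. Relative to compound 1 the change is 1-isopropylpiperidin-4-yl in place of 4-isopropylpiperazin-1-yl on a saturated ring carbon. The group that leaves and the group that enters are both six-membered saturated rings carrying an isopropyl on nitrogen; one ring nitrogen becomes a ring carbon and one acceptor is lost. Within the data shown here, with no measured step of this type, the expectation rests on compound 1 alone and on the modest size of the change. A step from compound 1 to compound 4 of a number 0.30 log units lower from compound 1 to compound 4 (within the scatter) is expected in this assay, that is a small shift downward, close to or within the scatter. Compound 4 is therefore estimated at 8.2 in this assay, with a range from 7.5 to 8.8.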

Compound 4, negative logarithm of the antagonist equilibrium constant: 9.3
Compound 4: the middle estimate sits 1.10 log units below what was measured; measured number above the stated range.
By their numbers in this assay, from the lowest: compound 3; then compounds 1 and 2 (each within the scatter of the next); then compound 4.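

In this assay, within the data shown here, 1-isopropylpiperidin-4-yl in place of 4-isopropylpiperazin-1-yl gives a number 0.80 log units higher from compound 1 to compound 4 (beyond the scatter) as the first characterised single step. This place, on a saturated ring carbon of the six-membered non-aromatic ring with 1 nitrogen, is therefore sensitive to a single ring atom in the entering group: one ring nitrogen becomes a ring carbon, one acceptor is lost, and the number rises. Nothing measured here accounts for the rise.

Only the isopropyl form of the new ring is shown, so the compounds leave open whether a methyl or cyclopropyl group on that ring nitrogen would hold the higher number. As far as these compounds go, it also remains open whether a 4-isopropylcyclohexyl group, with the remaining ring nitrogen replaced by carbon, would keep it.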